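The compounds below may be only part of what the source reports. "The series", "measured", "known", "first", "only" and "open" are said of these compounds alone.

Among the measured compounds shown here, compound 1 `COc1cc2c(cc1OC)C(CC(=O)Nc1ccccc1)CC2` gives 32% in a functional assay on the whole organism (strain Wistar) for inhibition, with Rattus norvegicus as the target, read by paw edema, with a stated time of 2 h, at a dose of 100 mg/kg (a lower number here means less inhibition, a higher number more inhibition at the dose given (going by the name of the read-out)), the highest of the two numbers measured so far. Its nearest neighbour is compound 2 `COc1cc2c(cc1OC)C(CC(=O)Nc1ccc(C)cc1)CC2`, which in this assay gives 26%; the step of a number 6 percentage points lower from compound 1 to compound 2 (within the scatter) lies within the scatter, so the two compounds cannot be told apart on these numbers. Compound 3 `COc1cc2c(cc1OC)C(CC(=O)Nc1ccncc1)CC2` differs from compound 1 in one place: pyridin-4-yl in place of phenyl on an amide-type nitrogen. For the measured compounds named here, the only measured step, a number 6 percentage points lower from compound 1 to compound 2 (within the scatter), concerns a methyl in place of hydrogen on an aromatic carbon, a different kind of change, and it was small. Going by the values given here, no step bearing directly on pyridin-4-yl in place of phenyl on an amide-type nitrogen has been measured. Compound 3 is therefore expected to show a step of a number 2 percentage points lower from compound 1 to compound 3 (within the scatter) that need not exceed the scatter. The estimate for compound 3 in this assay is 30%, between 14% and 46%.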

Compound 3, a percentage reported as inhibition, in the whole organism at one dose (the size of the read-out at that dose, not a potency): 44%
Compound 3: middle estimate off by 14 percentage points, on the low side, and the stated range covers the measured number.
By their numbers in this assay, from the lowest: compounds 2 and 1 (each within the scatter of the next); then compound 3.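

Among the compounds shown here, on the amide-type nitrogen, the aromatic group makes a difference in this assay: pyridin-4-yl in place of phenyl gives a number 12 percentage points higher from compound 1 to compound 3 (beyond the scatter), the first step to clear the scatter. Replacing 4-methylphenyl with the same pyridin-4-yl gives a number 18 percentage points higher from compound 2 to compound 3 (beyond the scatter), so compound 3 stands apart from both carbon-only aryl amides, which themselves cannot be told apart. Nothing available explains why this exchange raises the number.

On these data alone, it remains open whether the gain depends on where the ring nitrogen sits, as pyridin-3-yl or pyridin-2-yl on the amide-type nitrogen would show. As far as these compounds go, it is equally open whether a ring that is not aromatic, such as cyclohexyl or piperidin-4-yl, would hold the gain.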